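The source may report more compounds than this note shows. Statements on the series, on what has been measured and on what is new or still open speak of the compounds shown alone.

Compound 3 `COc1ccc(S(=O)(=O)NC2=NCCN2C(=S)SN2CCn3c2nsc3=S)cc1OC` is one of three compounds built on a shared core and tested in a functional assay on KYSE-510 cells (Homo sapiens) for antiproliferative activity, read by crystal violet staining, with a stated time of 96 h; a higher number here means a weaker inhibitor of growth, a lower number a stronger inhibitor of growth. In this assay compound 3 gives only a limit, >= 20000 nM, and not a number. Compound 1 `COc1ccc(S(=O)(=O)NC2=NCCN2C(=S)SN2CCn3c2nsc3=S)cc1` likewise reaches only a limit in this assay, >= 20000 nM. Compound 2 `COc1ccc(OC)c(S(=O)(=O)NC2=NCCN2C(=S)SN2CCn3c2nsc3=S)c1` also gives only a limit, >= 20000 nM. The steps a step that the two limits leave unreadable from compound 1 to compound 2, a step that the two limits leave unreadable from compound 1 to compound 3 and a step that the two limits leave unreadable from compound 2 to compound 3 are unreadable because of the limit of >= 20000 nM in this assay, at which 3 of the 3 values shown sit. Compound 4 `O=S(=O)(NC1=NCCN1C(=S)SN1CCn2c1nsc2=S)c1ccccc1Cl` differs from compound 3 by 2-chlorophenyl in place of 3,4-dimethoxyphenyl on a sulfonyl sulfur. Within the data shown here, no measured step shows any effect of such a change, so nothing beyond the scatter is expected. Compound 4 is estimated at 20000 nM, within a range from 5000 nM to 80000 nM, most probably again only a limit. The step expected from compound 3 to compound 4 is a number no higher from compound 3 to compound 4 (the limit leaves the size open).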

Compound 4, concentration for 50% growth inhibition: >= 20000 nM
Compound 4 ended at the assay's limit; the forecaster's own chance of this, stated with the estimate: 75%; the middle value sits exactly at the limit.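

Among these compounds, no step from compound 1, compound 2 or compound 3 to compound 4 can be read, because all these values are limits and not numbers: the limit of >= 20000 nM in this assay, at which 4 of the 4 values shown sit. The compounds shown leave open whether changing the group on the sulfonyl sulfur affects growth inhibition at all.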